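A few compounds are considered here, and "the series" means these few. Any claim that something is new, unique, unknown or untested is made for them only; others in the source may bear on it.

Measured compounds:
compound 1 `O=C(NCCCCc1ccccc1)n1cc(-c2ccccc2)oc1=O` — 90 nM
compound 2 `O=C(NCCCCc1ccccc1)n1cc(-c2ccccn2)oc1=O` — 25 nM
compound 3 `O=C(NCCCCc1ccccc1)n1cc(-c2cccnc2)oc1=O` — 70 nM

In an assay on isolated protein for inhibition of acid ceramidase (Homo sapiens), read by LC-MS, with a stated time of 1 h (a higher number here means a weaker inhibitor, a lower number a stronger inhibitor), compound 1 gives 90 nM, the highest of the three numbers: compound 3 sits nearest to it, compound 2 furthest. Compound 4 `O=C(NCCCCc1ccccc1)n1cc(-c2cscn2)oc1=O` differs from compound 1 in one place: 1,3-thiazol-4-yl in place of phenyl on an aromatic carbon. For the measured compounds named here, the steps that bear on this change are the two earlier swaps of phenyl for a heteroaromatic ring on the same aromatic carbon. There was a 3.6-fold lower number from compound 1 to compound 2 (0.56 log units; beyond the scatter), a change beyond the scatter, whereas there was a 1.3-fold lower number from compound 1 to compound 3 (0.11 log units; within the scatter), a change within it; between the two heteroaromatic rings there was a 2.8-fold higher number from compound 2 to compound 3 (0.45 log units; beyond the scatter). Both replacements of phenyl moved the number down or left it unchanged, none moved it up. Compound 4 is therefore expected to give a somewhat lower number than compound 1, about a 2.0-fold lower number from compound 1 to compound 4 (0.30 log units; within the scatter) in this assay, with the lower end of the range near the number of compound 2 and the upper end near that of compound 1. The estimate for compound 4 is 45 nM, within a range from 15 nM to 130 nM.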

Compound 4, half-maximal inhibitory concentration: 44 nM
Compound 4: middle estimate off by 1.0-fold (0.01 log units), on the high side, within the range that was stated.
By their numbers in this assay, from the lowest: compounds 2, 4, 3 and 1 (each within the scatter of the next, the first and the last beyond it).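

In this assay, the aromatic carbon next to the ring oxygen accepts a five-membered aromatic ring with 2 hetero atoms in place of phenyl: 1,3-thiazol-4-yl gives a 2.0-fold lower number from compound 1 to compound 4 (0.31 log units; beyond the scatter). That ring is not separated from either pyridine, with a 1.6-fold lower number from compound 3 to compound 4 (0.20 log units; within the scatter) and a 1.8-fold higher number from compound 2 to compound 4 (0.25 log units; within the scatter). Of the three replacements of phenyl, compound 2 and compound 4 lie beyond the scatter from compound 1, while compound 3 goes against this pattern and stays within it.

Nothing available here explains why these rings differ from phenyl or from one another. On these data alone, it remains open how a 1,3-thiazol-2-yl or 1,3-thiazol-5-yl group, a saturated cyclohexyl ring, or a thiazole carrying an amine or a carboxylic acid would read in this assay.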